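The source may hold more compounds than are shown below. What is called first, only, known or untested is meant among the compounds shown, and "the series" means these compounds.

In an ADME assay on MT4 cells (Homo sapiens) for activation, read by MTT assay (on this read-out higher numbers stand for lower toxicity in this test and lower numbers for higher toxicity in this test), compound 1 `CCCSc1nc(C(C)c2c(F)cccc2Cl)cc(=O)[nH]1` gives > 75000 nM, a limit and not a number. Compound 2 `CC(c1cc(=O)[nH]c(SC2CCCC2)n1)c1c(F)cccc1Cl` also gives only a limit, > 71000 nM. For the measured compounds named here, the one measured step, a step that the two limits leave unreadable from compound 1 to compound 2, is cyclopentyl in place of propyl on a sulfur, and it lies at a different place from the change now in question. Compound 3 `CCCSc1nc(C(C)c2c(F)cccc2Cl)c(CC)c(=O)[nH]1` carries ethyl in place of hydrogen on an aromatic carbon, (ethyl in place of hydrogen on an aromatic carbon). With no readable step to carry over, no change beyond the scatter is expected in this assay. The estimated step is an at least 1.2-fold lower number from compound 1 to compound 3 (0.09 log units; that floor lies within the scatter). For compound 3 the expected value is 60000 nM, with an expected range of 20000 nM to 110000 nM.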

Compound 3, half-maximal cytotoxic concentration: > 3000 nM
Compound 3 ended at the assay's limit; the forecaster's own chance of this, stated with the estimate: 65%; the middle value lies beyond the limit too.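

Compound 1 and compound 3 both end in limits and not numbers, so the step from one to the other cannot be read. On these data alone, whether ethyl in place of hydrogen on an aromatic carbon changes the read-out at all stays open.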